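A few compounds are considered here, and "the series" means these few. Any claim that something is new, unique, unknown or untested is made for them only; others in the source may bear on it.

Measured compounds in a functional assay on MDA-MB-231 cells (Homo sapiens) for antiproliferative activity, read by MTT assay, with a stated time of 24 h; on this read-out lower numbers stand for stronger inhibition and higher numbers for weaker inhibition:
- compound 1 `COc1ccc(-c2cc(C(=O)/C=C/c3cc(OC)c(OC)c(OC)c3)nc3cc(-c4ccccc4)nn23)cc1OC`: 16700 nM
- compound 2 `COc1ccc(C(=O)/C=C/c2cc(-c3ccc(OC)c(OC)c3)n3nc(-c4ccccc4)cc3n2)cc1`: 13900 nM
- compound 3 `COc1ccc(-c2cc(/C=C/C(=O)c3ccccc3)nc3cc(-c4ccccc4)nn23)cc1OC`: 11800 nM

All three compounds share the same core and differ only in the unsaturated ketone chain and its methoxy pattern. On these numbers compound 3 stands within the usual scatter of both compound 2 and compound 1, so no order among the three can be claimed. Going by the values given here, the one step available between neighbours, a 1.2-fold lower number from compound 2 to compound 3 (0.07 log units; within the scatter), shows that removing a methoxy group from the aromatic ring of the chain barely moves the read-out.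

Compound 4 `COc1ccc(/C=C/C(=O)c2cc(-c3ccc(OC)c(OC)c3)n3nc(-c4ccccc4)cc3n2)cc1` is the next step from compound 3: (2-(4-methoxyphenyl)ethenyl)carbonyl in place of 2-benzoylethenyl on an aromatic carbon. It thus turns the chain around and adds a methoxy group on its outer ring. Among the compounds with values here, no measured pair isolates the turning of the chain on its own; compound 2 and compound 3 together only show that the methoxy group matters little. Given a 1.2-fold lower number from compound 2 to compound 3 (0.07 log units; within the scatter), the expectation is that compound 4 will show no step beyond the scatter, with a 1.1-fold higher number from compound 3 to compound 4 (0.04 log units; within the scatter). Compound 4 is therefore estimated at 13000 nM, with a range from 6000 nM to 28000 nM.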

Compound 4, half-maximal inhibitory concentration: 22000 nM
Compound 4: the middle estimate sits 1.7-fold (0.23 log units) below what was measured, within the range that was stated.
By their numbers in this assay, from the lowest: compounds 3, 2, 1 and 4 (each within the scatter of the next).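

In this assay, compound 2 and compound 4 give the first clean view of turning the chain around at this position, since they differ only in which end of the chain carries the carbonyl: the step is a 1.6-fold higher number from compound 2 to compound 4 (0.20 log units; within the scatter), and the broader swap of 2-benzoylethenyl for (2-(4-methoxyphenyl)ethenyl)carbonyl gives a 1.9-fold higher number from compound 3 to compound 4 (0.27 log units; within the scatter). With the chain in its turned form, the outer ring also tolerates 4-methoxyphenyl in place of 3,4,5-trimethoxyphenyl, with a 1.3-fold higher number from compound 1 to compound 4 (0.12 log units; within the scatter), so on these four compounds neither the direction of the chain nor this change in the methoxy pattern separates one compound from another. Nothing on hand explains why these numbers stay so close together.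

Going by these compounds, all four compounds keep an unsaturated ketone chain ending in a benzene ring, so it remains open whether an amine or a carboxylic acid on that outer ring, or a longer chain between the ring and the shared core, would produce a step beyond the scatter. On these data alone, it is also open whether a hydroxy group in place of a methoxy group on the 3,4-dimethoxyphenyl group would do so.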